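Methoxybenzyl for methylphenyl on the shared core

The source may hold more compounds than are shown below. What is called first, only, known or untested is meant among the compounds shown, and "the series" means these compounds.

Notes on three measured compounds and one awaiting measurement. In a functional assay on L1210 cells (Mus musculus) for inhibition, read by cell counting, with a stated time of 2 days (on this read-out lower numbers stand for stronger inhibition and higher numbers for weaker inhibition), compound 3 `C=C(Br)C(=O)Nc1cccc(-c2cn3nc(-c4ccc(C)cc4)sc3n2)c1` gives 920 nM, the lowest of the three numbers. Compound 1 `C=C(Br)C(=O)Nc1cccc(-c2cn3nc(Cc4cccc(OC)c4)sc3n2)c1` gives 2000 nM and stands nearest to it, while compound 2 `COc1ccc(Cc2nn3cc(-c4cccc(N)c4)nc3s2)cc1` gives 227000 nM and lies furthest off. Going by the values given here, the one single-point step among the measured compounds is a 2.2-fold lower number from compound 1 to compound 3 (0.34 log units; beyond the scatter), a modest step.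

Compound 4 `C=C(Br)C(=O)Nc1cccc(-c2cn3nc(Cc4ccc(OC)cc4)sc3n2)c1` differs from compound 3 in one place: 4-methoxybenzyl in place of 4-methylphenyl on an aromatic carbon. Among the compounds with values here, the step from compound 1 to compound 3 is the only measured step that bears on this change, since it also exchanges a methoxybenzyl for the 4-methylphenyl, though with 3-methoxybenzyl rather than 4-methoxybenzyl; that step ran to a lower number, so the reverse exchange here is expected to run to a higher number of roughly the same size. Compound 4 is therefore expected to land near the number of compound 1, with the uncertainty that the two methoxybenzyl groups are not the same. The estimated step is a 2.2-fold higher number from compound 3 to compound 4 (0.34 log units; beyond the scatter). For compound 4 the estimate is 2000 nM, with a range from 800 nM to 5000 nM.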

Compound 4, half-maximal inhibitory concentration: 1400 nM
Beside the measured number, compound 4's estimate is 1.4-fold (0.15 log units) above it; the range from low to high includes it.
By their numbers in this assay, from the lowest: compounds 3, 4 and 1 (each within the scatter of the next, the first and the last beyond it); then compound 2.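

In this assay, the direct exchange at this aromatic carbon gives a 1.5-fold higher number from compound 3 to compound 4 (0.18 log units; within the scatter) and so does not separate 4-methoxybenzyl from 4-methylphenyl, although a 2.2-fold lower number from compound 1 to compound 3 (0.34 log units; beyond the scatter) had suggested that a methoxybenzyl group might cost something here. Moving the methoxy group gives a 1.4-fold lower number from compound 1 to compound 4 (0.15 log units; within the scatter) and again shows no separation, so compound 1 and compound 3 stand apart only as the two ends of a set whose neighbouring members cannot be told apart. Going by these compounds alone, the first single-place reading of the (1-bromoethenyl)carbonyl group on the nitrogen is a 160-fold lower number from compound 2 to compound 4 (2.21 log units; beyond the scatter) and far exceeds every step seen at the carbon position, so in these compounds the number depends much more on that group than on the choice among the three groups tested at the carbon.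

Nothing available accounts for any of these steps. On these data alone, whether an amine, a carboxylic acid or a longer chain on this same carbon would keep the number close to those of compound 1, compound 3 and compound 4 remains open.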